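Swapping the aryl group on a triazole-linked bicyclic amide

This account rests on a few compounds, and the source may have more. Where it says the series, first, only, none or still open, it means among the compounds named here.

Three compounds sharing one bicyclic amide core, each carrying a different aryl group on the triazole nitrogen, have been tested in a functional assay on LoVo cells (Homo sapiens) for inhibition, read by MTT assay, with a stated time of 24 h; on this read-out lower numbers stand for stronger inhibition and higher numbers for weaker inhibition. Compound 1 `CC1(C)[C@H]2CC[C@]1(C)N(Cc1cn(-c3ccccc3C#N)nn1)C(=O)C2` gives 140 nM, the highest of the three numbers. Compound 2 `CC1(C)[C@H]2CC[C@]1(C)N(Cc1cn(-c3ccccc3)nn1)C(=O)C2` gives 50 nM, and compound 3 `CC1(C)[C@H]2CC[C@]1(C)N(Cc1cn(-c3ccc(Br)cc3)nn1)C(=O)C2` gives 60 nM. The step of a 2.8-fold lower number from compound 1 to compound 2 (0.45 log units; beyond the scatter) comes with hydrogen in place of cyano on an aromatic carbon, and the step of a 2.3-fold lower number from compound 1 to compound 3 (0.37 log units; beyond the scatter) comes with 4-bromophenyl in place of 2-cyanophenyl on an aromatic nitrogen. Between the two unsubstituted-or-bromo compounds the step of a 1.2-fold higher number from compound 2 to compound 3 (0.08 log units; within the scatter) is small.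

Compound 4 `Cc1cccc(-n2cc(CN3C(=O)C[C@@H]4CC[C@@]3(C)C4(C)C)nn2)c1` differs from compound 1 as follows: 3-methylphenyl in place of 2-cyanophenyl on an aromatic nitrogen. Both earlier steps from compound 1 bear on this change, since each removes the cyano group, and both gave a modest lowering of the number. Adding a bromo group to the plain phenyl changed little, which suggests that a small substituent on the phenyl ring may again matter little. The expected step is therefore a 2.5-fold lower number from compound 1 to compound 4 (0.41 log units; beyond the scatter), a modest lowering. Compound 4 is estimated to give 55 nM in this assay, with a range from 25 nM to 130 nM.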

Compound 4, half-maximal inhibitory concentration: 50 nM
Beside the measured number, compound 4's estimate is 1.1-fold (0.04 log units) above it; measured number inside the range.
By their numbers in this assay, from the lowest: compounds 2, 4 and 3 (each within the scatter of the next); then compound 1.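

Replacing 2-cyanophenyl with 3-methylphenyl on the aromatic nitrogen brings a 2.8-fold lower number from compound 1 to compound 4 (0.45 log units; beyond the scatter) in this assay and so adds a third aryl group without a nitrile that lies beyond the scatter from the nitrile-bearing compound. Among those three aryl groups, the substituent shows no clear effect: adding a methyl group to the plain phenyl gives no change at the digits printed from compound 2 to compound 4 (within the scatter) and 3-methylphenyl in place of 4-bromophenyl gives a 1.2-fold lower number from compound 3 to compound 4 (0.08 log units; within the scatter), so plain phenyl, 3-methylphenyl and 4-bromophenyl all lie within the scatter of one another. Nothing measured here explains why the nitrile-bearing compound stands apart from the other three.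

The compounds shown include only one aryl group with a nitrile, so they cannot separate the effect of the nitrile itself from that of its place in 2-cyanophenyl. The phenyl substituents shown are limited to cyano, bromo and methyl, which leaves open how an amine or a carboxylic acid on that ring would read in this assay.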